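This account rests on a few compounds, and the source may have more. Where it says the series, first, only, none or still open, it means among the compounds named here.

Measured compounds:
compound 1 `CCCC1=C(C(=O)OCC)C(c2cccc([N+](=O)[O-])c2)C(C(=O)OCC)=C(C)N1`: 18 nM
compound 2 `CCOC(=O)C1=C(C)NC(COC)=C(C(=O)OC)C1c1ccccc1[N+](=O)[O-]`: 1760 nM

Two compounds have been run in a functional assay on HEK293 cells for antagonist activity at Voltage-dependent L-type calcium channel subunit alpha-1C (Oryctolagus cuniculus), read by FLIPR; a lower number here means a stronger inhibitor, a higher number a weaker inhibitor. Compound 1 gives 18 nM in this assay, and compound 2 gives 1760 nM. For the measured compounds named here, of these two numbers, the one for compound 1 is the lower, and the gap between the two compounds is well beyond the usual scatter of the measurement, so compound 1 is the stronger inhibitor of the pair. Going by the values given here, the two compounds differ in more than one place, and no single step is defined between them.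

Compound 3 `CCOC(=O)C1=C(C)NC(COC(=O)c2ccccc2)=C(C(=O)OCC)C1c1cccc([N+](=O)[O-])c1` has not yet been measured. It differs from compound 1 in one place: benzoyloxy in place of ethyl on a saturated chain carbon bound to a double-bonded ring carbon. Among the compounds with values here, no measured pair shows this change, so the size of its effect on this assay has to be guessed. The shared core and the nitro-bearing aryl ring of compound 1 are kept, and the change sits on the side chain only, so compound 3 is expected to stay near compound 1, perhaps somewhat weaker. The expected step is a 2.2-fold higher number from compound 1 to compound 3 (0.35 log units; beyond the scatter). For compound 3 in this assay the estimate is 40 nM, with a range from 8 nM to 200 nM.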

Compound 3, half-maximal inhibitory concentration: 210 nM
For compound 3 the middle estimate is 5.3-fold (0.72 log units) below the measured one; measured number above the stated range.
By their numbers in this assay, from the lowest: compound 1; then compound 3; then compound 2.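

In this assay, for the compounds shown here, putting benzoyloxy in place of ethyl on a saturated chain carbon bound to a double-bonded ring carbon gives a 12-fold higher number from compound 1 to compound 3 (1.07 log units; beyond the scatter), a large step and the first single-place change that can be read in this set. It shows that this position is not indifferent to what it carries: the swap from propyl to (benzoyloxy)methyl, seen from one bond further out, adds a six-membered aromatic ring and brings 9 heavy atoms where 2 stood, and the number rises clearly, although compound 3 still gives 210 nM and so remains an inhibitor in this assay. Nothing available accounts for the size of this step.

This single pair cannot separate what the aromatic ring contributes from what the two oxygens of the benzoyloxy group contribute, so the step belongs to the whole group only. As far as these compounds go, how a smaller hydroxymethyl, a primary amine or a carboxylic acid on the same chain carbon would read in this assay remains open, as does whether the step would keep its size on another core.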